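Nitro in place of methyl on a thiadiazole-fused core

The compounds below may be only part of what the source reports. "The series", "measured", "known", "first", "only" and "open" are said of these compounds alone.

Measured compounds:
Compound 1 `Clc1ccc(Cc2nn3c(Br)c(-c4ccc(Cl)cc4)nc3s2)cc1` gives in an ADME assay on CCRF-CEM cells (Homo sapiens) for cytotoxicity, with a stated time of 72 h (on this read-out higher numbers stand for weaker inhibition and lower numbers for stronger inhibition), a value that is a limit of the assay, > 250000 nM.
Compound 2 `Clc1ccc(Cc2nn3c(Br)c(-c4ccc(Br)cc4)nc3s2)cc1` gives in this assay 238000 nM.
Compound 3 `Cc1ccc(-c2nc3sc(Cc4ccc(Cl)cc4)nn3c2Br)cc1` gives in this assay a value that is again a limit, > 250000 nM.

Compound 3 therefore stands where compound 1 also sits, at the limit of > 250000 nM in this assay, at which 2 of the 3 values shown sit, and its number is not read. Compound 4 `O=[N+]([O-])c1ccc(-c2nc3sc(Cc4ccc(Cl)cc4)nn3c2Br)cc1` differs from compound 3 by nitro in place of methyl on an aromatic carbon. Among the measured compounds shown here, two measured steps touch the same place: a step that the two limits leave unreadable from compound 1 to compound 3, and an at least 1.0-fold higher number from compound 2 to compound 3 (0.02 log units; that floor lies within the scatter). Neither step involves a nitro group, and the measured change from chloro through bromo to methyl never moved the read-out beyond the scatter. The expectation for compound 4 in this assay is therefore an at least 1.0-fold lower number from compound 3 to compound 4 (0.01 log units; that floor lies within the scatter), a change of no size beyond the scatter, with a real chance that the assay again reports only a limit. The estimated value for compound 4 is 240000 nM, expected to lie between 100000 nM and 260000 nM.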

Compound 4, half-maximal inhibitory concentration: 73000 nM
Estimate against measurement, compound 4: 3.3-fold (0.52 log units) above; measured number outside the range, below it.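

In this assay, the position para to a large group on the six-membered aromatic ring turns out to respond to the group placed there: the readable steps among chloro, bromo and methyl stayed within the scatter, while nitro brings an at least 3.4-fold lower number from compound 3 to compound 4 (0.53 log units; beyond the scatter). Nitro also stands apart from the other two groups, with a 3.3-fold lower number from compound 2 to compound 4 (0.51 log units; beyond the scatter) and an at least 3.4-fold lower number from compound 1 to compound 4 (0.53 log units; beyond the scatter). Among the compounds shown here, only the step from bromo has a fixed size; the steps from methyl and chloro are floors, and the true changes may be larger, because compounds 1 and 3 sit at a limit of the assay: the limit of > 250000 nM in this assay, at which 2 of the 4 values shown sit.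

As far as these compounds go, whether a nitrile, a carboxylic acid or an amine at this position would also lower the number remains open. Why nitro differs from the other groups also remains open, as does whether it would have the same effect elsewhere on this ring.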